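The source may report more compounds than this note shows. Statements on the series, on what has been measured and on what is new or still open speak of the compounds shown alone.

Within the data shown here, in a functional assay for antagonist activity at C-X-C chemokine receptor type 3 (Homo sapiens) (a higher number here means a weaker inhibitor, a lower number a stronger inhibitor), compound 1 `CNC(=O)c1cnc(N2CCN(C3CCN(Cc4ccc(Cl)cc4)CC3)[C@@H](C)C2)c(Cl)c1` gives 32 nM, the lowest of the three numbers measured so far. Compound 2 `CNC(=O)c1cnc(N2CCN(C3CCN(Cc4cccs4)CC3)[C@@H](C)C2)c(Cl)c1` gives 1980 nM, and compound 3 `CNC(=O)c1cnc(N2CCN(C3CCN(C(=O)c4ccc(Cl)cc4)CC3)[C@@H](C)C2)c(Cl)c1` gives 210 nM. The two measured steps away from compound 1 were a 62-fold higher number from compound 1 to compound 2 (1.79 log units; beyond the scatter) and a 6.6-fold higher number from compound 1 to compound 3 (0.82 log units; beyond the scatter), and between the other pair the step was a 9.4-fold lower number from compound 2 to compound 3 (0.97 log units; beyond the scatter). All three of these changes sit on the amine nitrogen in a ring, and the methylcarbamoyl group stays the same throughout.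

Compound 4 `C[C@H]1CN(c2ncc(C(=O)NCC3CCCCC3)cc2Cl)CCN1C1CCN(Cc2ccc(Cl)cc2)CC1` differs from compound 1 in that group alone: cyclohexyl in place of hydrogen on a saturated chain carbon bound to an amide-type nitrogen. Among the measured compounds shown here, none of the measured steps touches a saturated chain carbon bound to an amide-type nitrogen, so the data give no direct guide to this change; they only show that changes elsewhere moved the number by modest to large amounts. Because compound 1 gives 32 nM and the entering group carries no donors or acceptors, the expected step is a 1.9-fold higher number from compound 1 to compound 4 (0.27 log units; within the scatter), about the size of the usual scatter, with wide uncertainty. Compound 4 is therefore estimated at 60 nM, with a range from 10 nM to 400 nM.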

Compound 4, half-maximal inhibitory concentration: 2.4 nM
Beside the measured number, compound 4's estimate is 25-fold (1.40 log units) above it; the measured number lies below the stated range.
By their numbers in this assay, from the lowest: compound 4; then compound 1; then compound 3; then compound 2.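

In this assay, the cyclohexyl group placed on a saturated chain carbon bound to an amide-type nitrogen gives a 13-fold lower number from compound 1 to compound 4 (1.12 log units; beyond the scatter), so turning methylcarbamoyl into (cyclohexylmethyl)carbamoyl lowers the number instead of leaving it unchanged or raising it. Among these compounds, the earlier compounds differ only on the amine nitrogen in a ring, so this is the first sign that the number also responds strongly to a change at this second place, here to a carbon-only ring of 6 heavy atoms. Nothing available here explains why the number falls with this change.

As far as these compounds go, whether the ring itself is needed stays open, and a phenyl ring or an open hexyl chain at this place would help to settle that. From the compounds shown here alone, it is also open whether the same change would lower the number for compound 2 or compound 3, which carry other groups on the amine nitrogen in a ring.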